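This account rests on a few compounds, and the source may have more. Where it says the series, first, only, none or still open, it means among the compounds named here.

Compound 1 `COc1cc(Cl)cc(-c2nn(-c3cccc(NC(=O)Nc4cccc(C(F)(F)F)c4)c3)cc2-c2ccncc2)c1` gives -11.7% in a functional assay on UACC-257 cells (Homo sapiens) for inhibition, read by sulforhodamine B assay, with a stated time of 48 h, tested at 10 uM (a lower number here means a stronger effect, a higher number a weaker effect of the compound at the concentration tested), the second highest of the three numbers in hand. Compound 2 `COc1cc(Cl)cc(-c2nn(-c3cccc(NC(=O)c4cccc(C(F)(F)F)c4)c3)cc2-c2ccncc2)c1` gives 68.7%, and compound 3 `O=C(Nc1cccc(-n2cc(-c3ccncc3)c(-c3cc(O)cc(Cl)c3)n2)c1)Nc1ccc(Cl)c(Cl)c1` gives -70.7%. Going by the values given here, the only single-change step recorded, a number 80.4 percentage points higher from compound 1 to compound 2 (beyond the scatter), alters the carbonyl substituent and not the aryl ring of the urea, so it does not bear on the change now considered. Compound 4 `COc1cc(Cl)cc(-c2nn(-c3cccc(NC(=O)Nc4ccc(Cl)c(Cl)c4)c3)cc2-c2ccncc2)c1` differs from compound 1 by 3,4-dichlorophenyl in place of 3-(trifluoromethyl)phenyl on an amide-type nitrogen. Among the compounds with values here, no step with this change is recorded; compound 3, which carries the same 3,4-dichlorophenyl urea on a different core, shows -70.7% against -11.7% for compound 1. Compound 4 is therefore expected to move a number 28.3 percentage points lower from compound 1 to compound 4 (beyond the scatter), to an estimated -40% with a range from -75% to 0%.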

Compound 4, a percentage reported as activity, at one concentration (the size of the read-out at that concentration, not a potency): -11.5%
Beside the measured number, compound 4's estimate is 28.5 percentage points below it; the range from low to high includes it.
By their numbers in this assay, from the lowest: compound 3; then compounds 1 and 4 (each within the scatter of the next); then compound 2.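

In this assay, the change on the amide-type nitrogen makes no difference that can be told from the scatter (a number 0.2 percentage points higher from compound 1 to compound 4 (within the scatter)), so with this core 3,4-dichlorophenyl and 3-(trifluoromethyl)phenyl cannot be told apart. The low number of compound 3 instead goes with the hydrogen on the oxygen (a number 59.2 percentage points higher from compound 3 to compound 4 (beyond the scatter)), while the gap to the amide remains with the 3,4-dichlorophenyl urea (a number 80.2 percentage points lower from compound 2 to compound 4 (beyond the scatter)). No measurement in hand explains these steps.
Open, from the compounds shown here alone, is whether an amine or a carboxylic acid on this aryl ring would shift the number, and whether a longer chain on the oxygen would.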